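A few compounds are considered here, and "the series" means these few. Any claim that something is new, unique, unknown or untested is made for them only; others in the source may bear on it.

For the measured compounds named here, compound 1 `CCCCCc1ccc(-c2cn(C[C@H](O)[C@H]3OC(=O)C(OCc4ccccc4)=C3OCc3ccccc3)nn2)cc1` gives the lowest of the two numbers so far in a functional assay on HepG2 cells (Homo sapiens) for antiproliferative activity, read by MTT assay, with a stated time of 72 h (a higher number here means a weaker inhibitor, a lower number a stronger inhibitor), at 7460 nM. Compound 2 `O=C1O/C(=C\Cn2cc(-c3cccc(O)c3)nn2)C(OCc2ccccc2)=C1OCc1ccccc1` gives 61700 nM in this assay, a higher number beyond the scatter. Compound 3 `O=C1O[C@H]([C@@H](O)Cn2ccnn2)C(OCc2ccccc2)=C1OCc1ccccc1` has not yet been measured in this assay. It differs from compound 1 by hydrogen in place of 4-pentylphenyl on an aromatic carbon. Going by the values given here, no step between measured compounds is available for this change, so the size of the step remains open; a move toward a higher number is expected for compound 3. The estimate for compound 3 in this assay is 30000 nM, between 8000 nM and 150000 nM, an expected step of a 4.0-fold higher number from compound 1 to compound 3 (0.60 log units; beyond the scatter).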

Compound 3, half-maximal inhibitory concentration: > 100000 nM
Compound 3: no number, only a limit; the forecaster's own chance of this, stated with the estimate: 20%; middle value at least 3.3-fold (0.52 log units) from the limit.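

In this assay, hydrogen in place of 4-pentylphenyl on an aromatic carbon of the five-membered aromatic ring with 3 nitrogen brings an at least 13-fold higher number from compound 1 to compound 3 (1.12 log units; beyond the scatter). Within this pair, the measurable activity of compound 1 therefore depends on having the 4-pentylphenyl group at this carbon. Compound 3 gives > 100000 nM, which is a limit of the assay and not a number, so the full size of the step stays unknown: the limit of > 100000 nM in this assay, at which 1 of the 3 values shown sits.

Still open, on these data alone, is whether the pentyl chain or the phenyl ring accounts for the step. Also open, as far as these compounds go, is whether an unsubstituted phenyl, a shorter chain or an amine at this carbon would keep the activity of compound 1.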